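The compounds below may be only part of what the source reports. "The series", "measured", "known", "first", "only" and "open" are said of these compounds alone.

Measured values in an assay on isolated protein for inhibition of sodium channel protein type 9 subunit alpha (Mus musculus), read by patch clamp; a lower number here means a stronger inhibitor, a higher number a weaker inhibitor:
compound 1 `O=C(Nc1ccccc1)C1CCN(CC(O)COc2ccc(C(F)(F)F)cc2)CC1`: 800 nM
compound 2 `O=C(c1ccccc1)c1ccccc1OCC(O)CN1CCC(C(=O)Nc2ccccc2)CC1`: 1000 nM
compound 3 `O=C1c2ccccc2CN1C1CCN(CC(O)COCc2ccc(C(F)(F)F)cc2)CC1`: 1500 nM

Compound 1 has the lowest of the three numbers, but its gaps to compound 2 and to compound 3 both fall within the usual scatter, so none of the three can be set apart from the others. Within the data shown here, no pair of measured compounds differs in only one place, so no step size has been established.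

Compound 4 `O=C1c2ccccc2CN1C1CCN(CC(O)COc2ccc(C(F)(F)F)cc2)CC1` is not yet measured. It differs from compound 1 thus: a group of 10 heavy atoms (8 carbon, 1 nitrogen, 1 oxygen; one five-membered non-aromatic ring with 1 hetero atom, one six-membered aromatic ring of carbon only) in place of a group of 9 heavy atoms (7 carbon, 1 nitrogen, 1 oxygen; one six-membered aromatic ring of carbon only), on a saturated ring carbon. Compound 3 carries the same entering group and gives 1500 nM, which suggests that the change from compound 1 to compound 4 should stay within the scatter, with at most a small drift toward a higher number. The expected step of a 1.3-fold higher number from compound 1 to compound 4 (0.10 log units; within the scatter) is therefore small. Compound 4 is estimated at 1000 nM, between 400 nM and 2500 nM.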

Compound 4, half-maximal inhibitory concentration: 100 nM
Compound 4: middle estimate off by 10-fold (1.00 log units), on the high side; the measured number lies below the stated range.
By their numbers in this assay, from the lowest: compound 4; then compounds 1, 2 and 3 (each within the scatter of the next).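

In this assay, among these compounds, the entering group in place of phenylcarbamoyl gives an 8.0-fold lower number from compound 1 to compound 4 (0.90 log units; beyond the scatter) on this saturated ring carbon, the first step that can be read, so activity responds to the group at this position. The entering group does not fix the value alone: compound 3 gives 1500 nM while compound 4 gives 100 nM with the same group. No data at hand bear on what underlies the step. Open, on these data alone, is whether the step holds with a nitrile or chlorine in place of trifluoromethyl. As far as these compounds go, an amine or carboxylic acid at this ring carbon also remains open.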